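The compounds below may be only part of what the source reports. "The series", "measured", "known", "first", "only" and "open" are said of these compounds alone.

Of the compounds shown here, three sharing a guanidine-hydrazone side chain have been tested in a functional assay on cells (Cancer cell lines, Homo sapiens) for inhibition; on this read-out higher numbers stand for weaker inhibition of growth and lower numbers for stronger inhibition of growth. Compound 1 `Cc1cc(-c2nc3sc(C)cn3c2/C=N/NC(=N)N)c(C)s1` gives 4470 nM in this assay. Compound 2 `Cc1cn2c(/C=N/NC(=N)N)c(-c3ccsc3)nc2s1` gives 7760 nM in this assay, and compound 3 `N=C(N)N/N=C/c1c(-c2ccsc2)nc2n1CCS2` gives 32400 nM in this assay, the highest of the three numbers. Compound 1 and compound 2 differ in one place, (2,5-dimethylthiophen-3-yl in place of thiophen-3-yl on an aromatic carbon), and the step is a 1.7-fold lower number from compound 2 to compound 1 (0.24 log units; within the scatter). Compound 2 and compound 3 differ in their cores; that difference is not broken down here, and the two values simply show compound 3 with the weaker inhibition of growth.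

Compound 4 `Cc1cc(-c2nc3n(c2/C=N/NC(=N)N)CCS3)c(C)s1` has not yet been measured. It relates to compound 3 as compound 1 relates to compound 2: 2,5-dimethylthiophen-3-yl in place of thiophen-3-yl on an aromatic carbon. The two places are the same kind of place but not identical in description: in compound 3 the aromatic carbon is also two ring bonds from two ring atoms that each bear a fused ring. Because the earlier step was a 1.7-fold lower number from compound 2 to compound 1 (0.24 log units; within the scatter), a step of similar size is expected here, a 1.6-fold lower number from compound 3 to compound 4 (0.21 log units; within the scatter). Compound 4 is therefore estimated at 20000 nM in this assay, most likely between 8000 nM and 45000 nM.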

Compound 4, concentration for 50% growth inhibition: 24000 nM
Compound 4: middle estimate off by 1.2-fold (0.08 log units), on the low side, and the stated range covers the measured number.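

In this assay, putting 2,5-dimethylthiophen-3-yl in place of thiophen-3-yl on this second core gives a 1.4-fold lower number from compound 3 to compound 4 (0.13 log units; within the scatter). Set beside the earlier step, the change behaves alike on the two cores, with no sign that the core alters its size: the same change on two cores in this assay, a 1.7-fold lower number (0.24 log units; within the scatter) from compound 2 to compound 1 and a 1.4-fold lower number (0.13 log units; within the scatter) from compound 3 to compound 4, 1.3-fold (0.11 log units) apart, within the scatter of two such steps Neither step lies beyond the scatter, however, so this agreement shows only that the change does little that can be detected on either core, not that it truly strengthens inhibition of growth, and two cores cannot speak for any other core.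

The compounds shown leave open whether a different group at this place on the five-membered aromatic ring, such as a phenyl ring or an amine, would give a step beyond the scatter. They also leave open whether such a step would carry from one core to the other as closely as this one does.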